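The source may hold more compounds than are shown below. What is called first, only, known or untested is meant among the compounds shown, and "the series" means these compounds.

Working notes on the series, read in an ADME assay on microsomes from liver (Homo sapiens) for metabolic stability; a higher number here means faster removal of the compound, a lower number slower removal. Compound 1 `CC(C)Oc1cc(Oc2ccc(S(C)(=O)=O)cc2)cc(-c2cccc(=O)[nH]2)c1` gives < 8 mL/min/kg, which is a limit. Compound 2 `CC(C)Oc1cc(Oc2ccc(S(C)(=O)=O)cc2)cc(-c2nccc(=O)[nH]2)c1` gives < 9.8 mL/min/kg, also a limit. From the compounds shown here alone, compound 3 `CC(C)Oc1cc(Oc2cnc(C(=O)N(C)C)cn2)cc(-c2nccc(=O)[nH]2)c1` gives < 8 mL/min/kg, again a limit, so its true standing is unknown. Compound 4 `COC[C@H](C)Oc1cc(Oc2cnc(C(=O)N(C)C)cn2)cc(-c2nccc(=O)[nH]2)c1` differs from compound 3 by methoxy in place of hydrogen on a saturated chain carbon, two bonds along the chain from an oxygen on an aromatic ring: isopropoxy to 1-(methoxymethyl)ethoxy. Within the data shown here, the one measured step, a step that the two limits leave unreadable from compound 1 to compound 2, lies on an aromatic carbon, not on the chain, and offers no size to carry over. The expectation therefore rests only on compound 3 and its limit of < 8 mL/min/kg. The expected step is a number no lower from compound 3 to compound 4 (the limit leaves the size open), with no change beyond the scatter anticipated in this assay. For compound 4 the estimate is 8 mL/min/kg, with an expected range of 4 mL/min/kg to 14 mL/min/kg.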

Compound 4, clearance in the Homo sapiens assay: < 8 mL/min/kg
Compound 4: no number, only a limit; the forecaster's own chance of this, stated with the estimate: 60%; the middle value sits exactly at the limit.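

In the Homo sapiens assay compound 3 gives < 8 mL/min/kg as a limit. In the Homo sapiens assay compound 4 gives < 8 mL/min/kg as a limit too. Both stand only as limits, so no step can be read between them. The compounds shown leave open whether methoxy in place of hydrogen on this chain carbon alters clearance at all. In a physicochemical assay for lipophilicity, using the shake flask method (on this read-out higher numbers stand for higher lipophilicity and lower numbers for lower lipophilicity), compound 3 gives 1.34 and compound 4 gives 0.81 as measured numbers. This is a number 0.53 log units lower from compound 3 to compound 4 (beyond the scatter) for the same change.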